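Swapping the Aryl Group on Compound 2's Amide

The source may hold more compounds than are shown below. What is called first, only, known or untested is meant among the compounds shown, and "the series" means these compounds.

Compound 1 `CN(C)C(=O)c1cc2cnc(Nc3ccc(N)cn3)nc2n1C1CCCC1`: 18.8%
Compound 2 `CN(C)C(=O)c1cc2cnc(Nc3ccc(NC(=O)C4(C(=O)Nc5cccc(O)c5)CC4)cc3)nc2n1C1CCCC1`: 80.7%

In a functional assay on T47D cells (Homo sapiens) for inhibition, read by CCK-8 assay, with a stated time of 72 h, tested at 1 uM (on this read-out higher numbers stand for more inhibition of growth at the one concentration tested and lower numbers for less inhibition of growth), compound 2 stands highest of the two at 80.7%, while compound 1 gives 18.8%. The gap between these two compounds lies outside the usual scatter. Compound 3 `CN(C)C(=O)c1cc2cnc(Nc3ccc(NC(=O)C4(C(=O)Nc5ccc(Br)cc5)CC4)cc3)nc2n1C1CCCC1` keeps the rest of compound 2 and changes one group: 4-bromophenyl in place of 3-hydroxyphenyl on an amide-type nitrogen. Here, 4-bromophenyl takes the place of 3-hydroxyphenyl on an amide-type nitrogen. Within the data shown here, no measured pair shows a change in one place, so the size of this step cannot be read from the data and remains uncertain. Compound 2 at 80.7% is the only reference that carries this side chain, and a small fall near the scatter is expected. The estimated change is a number 10.7 percentage points lower from compound 2 to compound 3 (beyond the scatter). In this assay, the expected value for compound 3 is 70%, within an estimated range of 45% to 88%.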

Compound 3, percent growth inhibition at one concentration: 21.1%
For compound 3 the middle estimate is 48.9 percentage points above the measured one; measured number outside the range, below it.
By their numbers in this assay, from the lowest: compounds 1 and 3 (each within the scatter of the next); then compound 2.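

Among these compounds, this is the only step that changes one place, and it shows that the aryl group on the amide-type nitrogen matters a great deal: in this assay, 4-bromophenyl in place of 3-hydroxyphenyl gives a number 59.6 percentage points lower from compound 2 to compound 3 (beyond the scatter). The two groups have the same count of heavy atoms and the same carbon ring, so a swap that leaves the size of the group unchanged by this count can still cost most of the growth inhibition. The data offer no measured reason for the drop.

The swap changes both the substituent and the number in the group's name, so the compounds shown leave open which of these matters. A 3-bromophenyl or 4-hydroxyphenyl group on the same nitrogen would separate the two, and 3-aminophenyl would show whether an amine can stand in for the hydroxyl.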